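The compounds below may be only part of what the source reports. "The series", "measured", "known", "first", "only" and "open" are said of these compounds alone.

Three compounds share one core and differ only in the group carried on an amine nitrogen in a ring. Compound 1 `Nc1scc(CN2CCN(c3cc(Cl)cc(Cl)c3)CC2)c1C(=O)c1ccc(Cl)cc1` gives 1% in an assay on CHO cells for displacement of a labelled ligand from adenosine receptor A3 (Homo sapiens), read by scintillation counting, with a stated time of 120 min, tested at 10 uM; a higher number here means more inhibition at the concentration tested (going by the name of the read-out), a lower number less inhibition. Compound 2 `Nc1scc(CN2CCN(c3ccc(Cl)cc3F)CC2)c1C(=O)c1ccc(Cl)cc1` gives 1% in this assay. Compound 3 `Nc1scc(CN2CCN(c3ccc(Cl)c(C(F)(F)F)c3)CC2)c1C(=O)c1ccc(Cl)cc1` gives 3% in this assay; this is the highest of the three numbers, yet the steps leading to it, a number 2 percentage points higher from compound 1 to compound 3 (within the scatter) and a number 2 percentage points higher from compound 2 to compound 3 (within the scatter), lie within the scatter, as does no change at the digits printed from compound 1 to compound 2 (within the scatter). Every exchange of that group seen so far has left the inhibition essentially unchanged and very low.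

Compound 4 `Nc1scc(CN2CCN(c3ccc(OC(F)(F)F)cc3)CC2)c1C(=O)c1ccc(Cl)cc1` keeps the same core, with the change (4-(trifluoromethoxy)phenyl in place of 4-chloro-3-(trifluoromethyl)phenyl on an amine nitrogen in a ring). All three measured steps bear on it, since each also swaps one group for another on the same amine nitrogen in a ring, and none moved the read-out beyond the scatter. The expected step is therefore a number 1 percentage points lower from compound 3 to compound 4 (within the scatter), which means no change beyond the scatter. Compound 4 is estimated to give 2% in this assay, within a range from 0% to 12%.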

Compound 4, a percentage reported as inhibition, at one concentration (the size of the read-out at that concentration, not a potency): 1%
Beside the measured number, compound 4's estimate is 1 percentage points above it; the measured number falls inside the stated range.
By their numbers in this assay, from the lowest: compounds 1, 2, 4 and 3 (each within the scatter of the next).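

Among the compounds shown here, putting 4-(trifluoromethoxy)phenyl in place of 4-chloro-3-(trifluoromethyl)phenyl on the amine nitrogen in a ring introduces the first group in this set with no chlorine and with an oxygen, yet this assay shows a number 2 percentage points lower from compound 3 to compound 4 (within the scatter), along with no change at the digits printed from compound 2 to compound 4 (within the scatter) and no change at the digits printed from compound 1 to compound 4 (within the scatter). Among these four compounds, then, removing chlorine from this group and adding a hydrogen-bond acceptor leaves the inhibition very low, and no group stands apart from the others. No measurement is available to explain this flat result.

On these data alone, all four groups are substituted phenyl rings, so it remains open whether a pyridine ring, a benzyl group or an acetyl group on that nitrogen would give a different number. Also open, as far as these compounds go, is whether an amine or a carboxylic acid added elsewhere on the shared core would raise the inhibition.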